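Ester to acid on the shared core, an expectation

The source may hold more compounds than are shown below. What is called first, only, known or untested is meant among the compounds shown, and "the series" means these compounds.

Measured so far in an assay on cells for antagonist activity at vitamin D3 receptor (Homo sapiens), read by a luciferase reporter; on this read-out higher numbers stand for weaker inhibition and lower numbers for stronger inhibition:
compound 1 `COC(=O)CCc1ccc(OCc2oc(-c3ccccc3OC)nc2C)cc1` gives 13600 nM
compound 2 `COC(=O)CCc1ccc(OCc2oc(-c3cccc(OC)c3)nc2C)cc1` gives 6700 nM

For the measured compounds named here, compound 2 holds the lower of the two numbers so far; the only measured step, a 2.0-fold lower number from compound 1 to compound 2 (0.31 log units; beyond the scatter), is modest but beyond the scatter and separates it from compound 1.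

Compound 3 `COc1cccc(-c2nc(C)c(COc3ccc(C(=O)O)cc3)o2)c1` has not yet been measured. It differs from compound 2 in one place: carboxy in place of 2-(methoxycarbonyl)ethyl on an aromatic carbon. Going by the values given here, no measured step bears on this change. Among the compounds with values here, the single step available, from compound 1 to compound 2, concerns the methoxyphenyl end of the shared core and says nothing about the 2-(methoxycarbonyl)ethyl group or what stands in for it. The account therefore rests on compound 2 alone, and with nothing to push the number either way, no step beyond the scatter is expected in this assay, though the change is not a small one and the range is kept wide.

Compound 3 is estimated at 6000 nM, with a range from 1500 nM to 24000 nM; this would mean an expected step of a 1.1-fold lower number from compound 2 to compound 3 (0.05 log units; within the scatter).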

Compound 3, half-maximal inhibitory concentration: > 80000 nM
Compound 3: no number, only a limit; the forecaster's own chance of this, stated with the estimate: 20%; middle value at least 13-fold (1.12 log units) away from the limit.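

In this assay, for the compounds shown here, this aromatic carbon, para to a large group, proves far less forgiving than the earlier compounds could show: carboxy in place of 2-(methoxycarbonyl)ethyl gives an at least 11-fold higher number from compound 2 to compound 3 (1.07 log units; beyond the scatter), a large step, whereas the only earlier step, at the methoxyphenyl end of the shared core, was modest. From the compounds shown here alone, the reading for compound 3 is a limit and not a number, so the true size of the step remains unknown: the limit of > 80000 nM in this assay, at which 1 of the 3 values shown sits. The change also does two things at once, removing the ester and shortening the group from the 2-(methoxycarbonyl)ethyl chain to carboxy on the aromatic carbon, and this single step cannot separate the two.

The compounds shown leave open whether 2-carboxyethyl, which keeps the chain but not the ester, or methoxycarbonyl, which keeps the ester but not the chain, would stay close to compound 2 at 6700 nM. They also leave open how an amide or a longer ester chain at this place would read in this assay.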